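Trimming 1-hydroxyethyl to hydroxymethyl in compound 1

This account rests on a few compounds, and the source may have more. Where it says the series, first, only, none or still open, it means among the compounds named here.

In an ADME assay on KB cells (Homo sapiens) for cytotoxicity, with a stated time of 48 h (on this read-out higher numbers stand for weaker inhibition and lower numbers for stronger inhibition), compound 1 (`CC1=CCC[C@](C)(CC/C(C)=C/CC2=C(O)C(=O)C=C(N[C@H](C(=O)O)[C@@H](C)O)C2=O)[C@@H]1C`) gives > 10 ug/mL as a limit and not a true number. Compound 2 (`C=C1[C@H](C)CCC[C@]1(C)CC/C(C)=C/CC1=C(O)C(=O)C=C(N[C@@H](C(=O)O)[C@H](C)O)C1=O`) gives > 10 ug/mL and this too is a limit. Compound 3 (`C=C1[C@H](C)CCC[C@]1(C)CC/C(C)=C/CC1=C(O)C(=O)C=C(N[C@H](C(=O)O)[C@@H](C)O)C1=O`) gives > 10 ug/mL and this is likewise a limit. The data thus show only the limit of > 10 ug/mL in this assay, at which 3 of the 3 values shown sit, and fix no exact position for compound 1.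

Compound 4 (`CC1=CCC[C@](C)(CC/C(C)=C/CC2=C(O)C(=O)C=C(N[C@@H](CO)C(=O)O)C2=O)[C@@H]1C`) departs from compound 1 at one place, where 1-hydroxyethyl becomes hydroxymethyl: hydrogen in place of methyl on a saturated chain carbon bound to an oxygen on a saturated carbon and a saturated chain carbon in the side chain that carries the carboxy group.

Two measured steps lie closest to this change. One is a step that the two limits leave unreadable from compound 1 to compound 3 and it alters the ring-bearing group instead. The other is a step that the two limits leave unreadable from compound 2 to compound 3 and it reflects the fact that compounds 2 and 3 differ only in the configuration as drawn without removing any atom. Neither gives a size to carry over, and neither exchanges methyl for hydrogen.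

No shift beyond the scatter is therefore expected in this assay and no direction can be favoured. The expected move is a step that the limit leaves unreadable from compound 1 to compound 4. It starts from compound 1, which holds the limit of > 10 ug/mL as a floor. For compound 4 a half-maximal inhibitory concentration of 12 ug/mL is estimated, with an expected range of 4 ug/mL to 30 ug/mL in this read-out.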

Compound 4, half-maximal inhibitory concentration: > 10 ug/mL
Compound 4 gave a limit, no number; the forecaster's own chance of this, stated with the estimate: 65%; the middle value is on the limit's open side.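

Compound 1 and compound 4 each give only a limit in this assay, so no new step can be read from this pair: the limit of > 10 ug/mL in this assay, at which 4 of the 4 values shown sit.

The compounds shown leave open where any of them truly lies beyond that limit, and whether hydrogen in place of methyl, the ring-bearing group or the configuration as drawn alters the read-out at all.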